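The source may report more compounds than this note shows. Statements on the series, on what has been measured and on what is new or still open speak of the compounds shown alone.

In a functional assay on BGC-823 cells (Homo sapiens) for cytotoxicity, read by MTT assay (a lower number here means a stronger inhibitor, a higher number a weaker inhibitor), compound 3 `Cc1cccc(Nc2nc(C)c(C(=O)/C=C/c3ccccc3)s2)c1` gives 13600 nM, the lowest of the two numbers shown, while compound 2 `Cc1nc(Nc2ccccc2)sc1C(=O)/C=C/c1ccccc1` gives 19500 nM. Among the measured compounds shown here, the only measured step, a 1.4-fold lower number from compound 2 to compound 3 (0.16 log units; within the scatter), lies within the scatter. Compound 1 `COc1ccc(/C=C/C(=O)c2sc(Nc3ccc(Cl)c(Cl)c3)nc2C)cc1` carries the same 3,4-dichlorophenyl that enters here, and in this assay compound 1 reaches only > 25000 nM, which is a limit of the assay and not a number. Compound 4 `Cc1nc(Nc2ccc(Cl)c(Cl)c2)sc1C(=O)/C=C/c1ccccc1` differs from compound 3 by 3,4-dichlorophenyl in place of 3-methylphenyl on a nitrogen on an aromatic ring. For the measured compounds named here, no measured step covers this change, and the step that is measured, a 1.4-fold lower number from compound 2 to compound 3 (0.16 log units; within the scatter), stayed within the scatter. Because compound 1 sits at the limit of > 25000 nM in this assay, at which 1 of the 3 values shown sits, the expected step is a 1.8-fold higher number from compound 3 to compound 4 (0.26 log units; within the scatter). Compound 4 is therefore estimated at 25000 nM, with a range from 10000 nM to 60000 nM.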

Compound 4, half-maximal inhibitory concentration: 10600 nM
For compound 4 the middle estimate is 2.4-fold (0.37 log units) above the measured one; the range from low to high includes it.
By their numbers in this assay, from the lowest: compounds 4, 3 and 2 (each within the scatter of the next). At a limit, above all of these: compound 1.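

In this assay, on a nitrogen on an aromatic ring, 3,4-dichlorophenyl in place of 3-methylphenyl gives a 1.3-fold lower number from compound 3 to compound 4 (0.11 log units; within the scatter), and in place of phenyl it gives a 1.8-fold lower number from compound 2 to compound 4 (0.26 log units; within the scatter), so these three groups cannot be told apart here. Among the compounds shown here, with 3,4-dichlorophenyl held constant, hydrogen in place of methoxy on an aromatic carbon gives an at least 2.3-fold lower number from compound 1 to compound 4 (0.37 log units; beyond the scatter), the only new step beyond the scatter, so the dichlorinated group alone does not set compound 1 apart. Compound 1 stands at a limit and not a number: the limit of > 25000 nM in this assay, at which 1 of the 4 values shown sits.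

The compounds shown leave open whether an amine or a carboxylic acid on this aromatic ring would separate from these groups. They also leave open whether methoxy has a similar effect when phenyl or 3-methylphenyl sits on the nitrogen.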